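From Chloro to Nitro: Estimating Compound 3

This account rests on a few compounds, and the source may have more. Where it says the series, first, only, none or still open, it means among the compounds named here.

Of the compounds shown here, two sharing one core have been measured in a functional assay on ECa-109 cells (Homo sapiens) for cytotoxicity, read by MTT assay, with a stated time of 48 h; on this read-out lower numbers stand for stronger inhibition and higher numbers for weaker inhibition. Compound 1 `O=C1C(O)=C(C(c2ccc(F)cc2)c2c[nH]c3ccccc23)C(=O)c2ccccc21` gives 28100 nM in this assay. Compound 2 `O=C1C(O)=C(C(c2ccc(Cl)cc2)c2c[nH]c3ccccc23)C(=O)c2ccccc21` gives 45800 nM in this assay and stands highest of the two numbers, with compound 1 as its nearest neighbour. Among the compounds with values here, the only measured step, a 1.6-fold higher number from compound 1 to compound 2 (0.21 log units; within the scatter), concerns a halogen swap on an aromatic carbon. Compound 3 `O=C1C(O)=C(C(c2cccc([N+](=O)[O-])c2)c2c[nH]c3ccccc23)C(=O)c2ccccc21` differs from compound 2 by 3-nitrophenyl in place of 4-chlorophenyl on a saturated chain carbon bound to an aromatic carbon and a double-bonded ring carbon. Within the data shown here, no measured step involves a nitro group, so the halogen step offers little direct guidance; that sole step lies within the scatter, and nothing in the data points to a move beyond it in this assay. Compound 3 is therefore expected to show a step of a 1.3-fold lower number from compound 2 to compound 3 (0.12 log units; within the scatter) in this assay. The estimate for compound 3 is 35000 nM, with a range from 12000 nM to 100000 nM.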

Compound 3, half-maximal inhibitory concentration: 36200 nM
For compound 3 the middle estimate is 1.0-fold (0.01 log units) below the measured one; low and high end bracket the measured number.
By their numbers in this assay, from the lowest: compounds 1, 3 and 2 (each within the scatter of the next).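

In this assay, 3-nitrophenyl in place of 4-chlorophenyl on a saturated chain carbon bound to an aromatic carbon and a double-bonded ring carbon leaves the number within the scatter (a 1.3-fold lower number from compound 2 to compound 3 (0.10 log units; within the scatter)), and the same holds for 3-nitrophenyl in place of 4-fluorophenyl (a 1.3-fold higher number from compound 1 to compound 3 (0.11 log units; within the scatter)). Within the data shown here, this position had so far been seen only through a halogen swap, and it now proves just as unresponsive to a nitro-bearing ring, so all three compounds read as one level in this assay. No available evidence accounts for this result.

Because the nitro group and its place on the ring changed in one step, their separate contributions cannot be read. As far as these compounds go, it also remains open whether an amine or a carboxylic acid on this phenyl ring, or a longer chain at this carbon, would shift the number beyond the scatter.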